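The source may hold more compounds than are shown below. What is called first, only, known or untested is meant among the compounds shown, and "the series" means these compounds.

In an assay on isolated protein for inhibition of phosphodiesterase 4A (Sus scrofa) (a higher number here means a weaker inhibitor, a lower number a stronger inhibitor), compound 1 `COc1ccc(C(=O)Nc2ccccc2C)cc1OC1CCCC1` gives 300 nM, compound 2 `COc1ccc(C(=O)Nc2ccccn2)cc1OC1CCCC1` gives 1000 nM, and compound 3 `COc1ccc(C(=O)Nc2ccncc2Cl)cc1OC1CCCC1` gives 16 nM. Compound 3 therefore stands at the lowest number of the three, the strongest inhibitor in this set: the step from compound 1 to compound 3 is a 19-fold lower number from compound 1 to compound 3 (1.27 log units; beyond the scatter), and the step from compound 2 to compound 3 is a 63-fold lower number from compound 2 to compound 3 (1.80 log units; beyond the scatter). Compound 4 `COc1ccc(C(=O)NC2(C)C=C(C)ON2)cc1OC1CCCC1` differs from compound 3 in one place: a group of 7 heavy atoms (5 carbon, 1 nitrogen, 1 oxygen; one five-membered non-aromatic ring with 2 hetero atoms) in place of a group of 7 heavy atoms (5 carbon, 1 nitrogen, 1 chlorine; one six-membered aromatic ring with 1 hetero atom), on an amide-type nitrogen. Going by the values given here, no measured step exchanges an aromatic ring for a non-aromatic one on this nitrogen, so no step bears on the change directly. What the measured steps do show is that the group on this nitrogen moves the number a long way, as in a 3.3-fold higher number from compound 1 to compound 2 (0.52 log units; beyond the scatter) alongside the two large steps above. Among the compounds with values here, since the entering ring resembles none of the measured groups, and both measured alternatives to the group of compound 3 gave clearly higher numbers, a weaker inhibitor is expected. Compound 4 is expected to give about 500 nM in this assay, within a range from 100 nM to 3000 nM, an expected step of a 31-fold higher number from compound 3 to compound 4 (1.49 log units; beyond the scatter).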

Compound 4, half-maximal inhibitory concentration: 450 nM
For compound 4 the middle estimate is 1.1-fold (0.05 log units) above the measured one; low and high end bracket the measured number.
By their numbers in this assay, from the lowest: compound 3; then compounds 1 and 4 (each within the scatter of the next); then compound 2.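

In this assay, a five-membered non-aromatic ring with 2 hetero atoms can replace the aromatic six-membered rings on the amide-type nitrogen without loss of inhibition in every comparison: exchanging the pyridin-2-yl group for it gives a 2.2-fold lower number from compound 2 to compound 4 (0.35 log units; beyond the scatter) in this series. Exchanging the 2-methylphenyl group gives a 1.5-fold higher number from compound 1 to compound 4 (0.18 log units; within the scatter), so these two groups cannot be told apart here, although one ring is aromatic and the other is not. The ring type alone therefore does not set the number, yet the 3-chloropyridin-4-yl group keeps a clear lead, as a 28-fold higher number from compound 3 to compound 4 (1.45 log units; beyond the scatter) shows.

From the compounds shown here alone, how a plain pyridin-4-yl group or a cyclohexyl group on this nitrogen would compare remains open. Nothing available here explains the differences among these groups.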